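A few compounds are considered here, and "the series" means these few. Any claim that something is new, unique, unknown or untested is made for them only; others in the source may bear on it.

Series notes. Compound 1 `Cc1cc(NC(=O)N2CCN(C)CC2)ccc1N1CCC(N2CCCC2C)C1` gives 12.7 nM in an assay on CHO cells for displacement of a labelled ligand from histamine receptor H3 (Macaca mulatta), read by scintillation counting, with a stated time of 1 h; on this read-out higher numbers stand for weaker inhibition and lower numbers for stronger inhibition. Compound 2 `CC(=O)N1CCN(C(=O)Nc2ccc(N3CCC(N4CCCC4C)C3)c(C)c2)CC1` gives 23 nM in this assay; the step of a 1.8-fold higher number from compound 1 to compound 2 (0.26 log units; within the scatter) is the only one on record and lies within the scatter, so the two numbers cannot be separated. Compound 2 holds the larger of the two numbers, but only by a margin within the scatter. Compound 3 `CC(=O)N(C)C1CCN(C(=O)Nc2ccc(N3CCC(N4CCCC4C)C3)c(C)c2)C1` is not yet measured. It differs from compound 2 by 3-(acetyl(methyl)amino)pyrrolidin-1-yl in place of 4-acetylpiperazin-1-yl on a carbonyl carbon. Going by the values given here, no measured step matches this change; the step in hand, acetyl in place of methyl on an amine nitrogen in a ring, shows only that a change at the group on the carbonyl carbon passed without a shift beyond the scatter. The expected step of a 1.3-fold higher number from compound 2 to compound 3 (0.12 log units; within the scatter) is therefore small, with no firm direction beyond the scatter. Compound 3 is estimated at 30 nM, range 10 nM to 90 nM.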

Compound 3, inhibition constant: 89.7 nM
Beside the measured number, compound 3's estimate is 3.0-fold (0.48 log units) below it, within the range that was stated.
By their numbers in this assay, from the lowest: compounds 1 and 2 (each within the scatter of the next); then compound 3.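

At the group on the carbonyl carbon, this assay now shows a change that passes beyond the scatter, whereas the earlier change from methyl to acetyl on the ring nitrogen did not. Putting 3-(acetyl(methyl)amino)pyrrolidin-1-yl in place of 4-acetylpiperazin-1-yl gives a 3.9-fold higher number from compound 2 to compound 3 (0.59 log units; beyond the scatter) and putting it in place of 4-methylpiperazin-1-yl gives a 7.1-fold higher number from compound 1 to compound 3 (0.85 log units; beyond the scatter), so this position tolerates some changes to the piperazine substituent but not this exchange of the whole group. No measurement on record accounts for the shift.

This exchange alters the ring size and the attached group together, so the compounds shown do not separate the two contributions. From the compounds shown here alone, how a pyrrolidine carrying a dimethylamino group or a carboxylic acid would read at this position remains open.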